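The source may hold more compounds than are shown below. What is called first, only, known or untested is meant among the compounds shown, and "the series" means these compounds.

Measured compounds:
- compound 1 `CCOC(=O)N1CCC(Oc2ncnc3c2CCN3c2ccc(S(C)(=O)=O)cc2F)CC1`: 135%
- compound 2 `CC(C)COC(=O)N1CCC(Oc2ncnc3c2CCN3c2ccc(S(C)(=O)=O)cc2F)CC1`: 94%
- compound 3 `CC(C)S(=O)(=O)N1CCC(Oc2ncnc3c2CCN3c2ccc(S(C)(=O)=O)cc2F)CC1`: 62%

In a functional assay on CHO-K1 cells with Glucose-dependent insulinotropic receptor (Homo sapiens) as the target, read by a luciferase reporter, with a stated time of 5 h (on this read-out lower numbers stand for smaller maximal responses and higher numbers for larger maximal responses), compound 3 stands lowest of the three, with a number 32 percentage points lower from compound 2 to compound 3 (beyond the scatter) and a number 73 percentage points lower from compound 1 to compound 3 (beyond the scatter) both beyond the scatter. Compound 4 `CN(C)S(=O)(=O)N1CCC(Oc2ncnc3c2CCN3c2ccc(S(C)(=O)=O)cc2F)CC1` keeps the sulfonamide of compound 3 and changes only the group on its sulfonyl sulfur: dimethylamino in place of isopropyl on a sulfonyl sulfur. Going by the values given here, no measured step touches this position; the steps seen so far, a number 41 percentage points lower from compound 1 to compound 2 (beyond the scatter) and a number 73 percentage points lower from compound 1 to compound 3 (beyond the scatter), concern the carbamate or its exchange for the sulfonamide, and both were large. The sulfonamide class is represented by compound 3 alone, so the swap of isopropyl for dimethylamino on the sulfonyl sulfur is expected to give a step about the size of the scatter or smaller, in no clear direction, a number 2 percentage points lower from compound 3 to compound 4 (within the scatter). Compound 4 is therefore estimated at 60%, within 40% to 85%.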

Compound 4, largest response reached (reported as percent of maximum), in percent of the reference or control that the assay uses: 68%
Compound 4: middle estimate off by 8 percentage points, on the low side, within the range that was stated.
By their numbers in this assay, from the lowest: compounds 3 and 4 (each within the scatter of the next); then compound 2; then compound 1.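

In this assay, dimethylamino in place of isopropyl on a sulfonyl sulfur gives a number 6 percentage points higher from compound 3 to compound 4 (within the scatter), so this position shows no readable shift for this exchange. Compound 4 also stays apart from both carbamates, with a number 26 percentage points lower from compound 2 to compound 4 (beyond the scatter) and a number 67 percentage points lower from compound 1 to compound 4 (beyond the scatter), so the gap to the carbamates now rests on two sulfonyl compounds rather than one. No evidence bearing on this result is available.

Still open, going by these compounds, is whether a longer chain or a cyclic amine on the sulfonyl sulfur would stay within the scatter of compound 3 and compound 4.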